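This account rests on a few compounds, and the source may have more. Where it says the series, first, only, none or still open, it means among the compounds named here.

Working notes on the series. Compound 1 `COc1cc(C(=O)/C=C\Nc2ccc(-c3nc4cc(OC)c(OC)c(OC)c4s3)cc2C)cc(OC)c1OC` shares its core with compound 2 `COc1ccc(C(=O)/C=C\Nc2ccc(-c3nc4cc(OC)c(OC)c(OC)c4s3)cc2C)cc1O` and compound 3 `COc1ccc(C(=O)/C=C\Nc2ccc(-c3nc4cc(OC)c(OC)c(OC)c4s3)cc2C)cc1F`. In a functional assay on MIA PaCa-2 cells (Homo sapiens) for antiproliferative activity, read by sulforhodamine B assay, with a stated time of 48 h (on this read-out higher numbers stand for weaker inhibition and lower numbers for stronger inhibition), compound 1 gives 22800 nM, the highest of the three numbers; in this assay compound 2 gives 15400 nM and compound 3 gives 1800 nM. The step of a 1.5-fold lower number from compound 1 to compound 2 (0.17 log units; within the scatter) is within the scatter, so no order is claimed between compound 1 and compound 2; the step of a 13-fold lower number from compound 1 to compound 3 (1.10 log units; beyond the scatter) is large and beyond it, as is an 8.6-fold lower number from compound 2 to compound 3 (0.93 log units; beyond the scatter).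

Compound 4 `COc1cc(C(=O)/C=C\Nc2ccc(-c3nc4cc(OC)c(OC)c(OC)c4s3)cc2C)c(Br)c(OC)c1OC` differs from compound 1 by one change: bromo in place of hydrogen on an aromatic carbon. Among the compounds with values here, none of the measured steps bears directly on it. Each of them replaces the whole 3,4,5-trimethoxyphenyl with another aryl group, whereas compound 4 keeps all three methoxy groups and adds a bromo. The measured steps show only that the substitution pattern of this ring can move the number, in one case strongly.

Compound 4 is therefore expected to sit near compound 1, with the step of a 1.1-fold lower number from compound 1 to compound 4 (0.06 log units; within the scatter) estimated as within the scatter and a wide range. For compound 4 the estimate is 20000 nM, between 6000 nM and 60000 nM.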

Compound 4, half-maximal inhibitory concentration: 24300 nM
Compound 4: the middle estimate sits 1.2-fold (0.08 log units) below what was measured, within the range that was stated.
By their numbers in this assay, from the lowest: compound 3; then compounds 2, 1 and 4 (each within the scatter of the next).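

In this assay, bromo in place of hydrogen on an aromatic carbon, ortho to a large group and ortho to a methoxy group, gives a 1.1-fold higher number from compound 1 to compound 4 (0.03 log units; within the scatter), so the two numbers cannot be told apart. The earlier steps shown here replaced the whole 3,4,5-trimethoxyphenyl, whereas this one keeps all three methoxy groups and shows that this position accepts a single bromine atom without a readable shift in the number, leaving the weak micromolar level of the trimethoxy series in place. No measurement here offers an explanation for this result.

Open, from the compounds shown here alone, is whether an amine, a carboxylic acid or a longer chain at this same position would leave the number equally unmoved. Also open, going by these compounds, is whether bromo at this position would leave the number of compound 3 as undisturbed, with its 3-fluoro-4-methoxyphenyl.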